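The source may hold more compounds than are shown below. What is called first, only, known or untested is meant among the compounds shown, and "the series" means these compounds.

Among the measured compounds shown here, compound 2 `CC(C)=CCC/C(C)=C/CC1Cc2c(OCc3ccccc3)cc(=O)n(CCCO)c2CC1(C)C` gives 46.5% in a functional assay on PANC-1 cells (Homo sapiens) for inhibition, read by MTT assay, with a stated time of 24 h, tested at 10 uM (a higher number here means more inhibition at the concentration tested (going by the name of the read-out), a lower number less inhibition), the higher of the two numbers so far, while compound 1 `CC(C)=CCC1Cc2c(OCc3ccccc3)cc(=O)n(CCCO)c2CC1(C)C` gives -0.3%. For the measured compounds named here, the one measured step, a number 46.8 percentage points higher from compound 1 to compound 2 (beyond the scatter), concerned a different place on the shared core and so offers no direct guide here. Compound 3 `CC(C)=CCC/C(C)=C/CC1Cc2c(OCCCOc3ccc(Cl)cc3)cc(=O)n(CCCO)c2CC1(C)C` differs from compound 2 by 2-(4-chlorophenoxy)ethyl in place of phenyl on a saturated chain carbon bound to an oxygen on an aromatic ring. Going by the values given here, no measured step bears on this change; the step of a number 0.5 percentage points lower from compound 2 to compound 3 (within the scatter) is expected to stay within the scatter, in no particular direction. Compound 3 is therefore estimated at 46%, with a range from 25% to 65%.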

Compound 3, a percentage reported as inhibition, at one concentration (the size of the read-out at that concentration, not a potency): 25.2%
Compound 3: middle estimate off by 20.8 percentage points, on the high side; low and high end bracket the measured number.
By their numbers in this assay, from the lowest: compound 1; then compound 3; then compound 2.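

In this assay, 2-(4-chlorophenoxy)ethyl in place of phenyl on a saturated chain carbon bound to an oxygen on an aromatic ring gave a number 21.3 percentage points lower from compound 2 to compound 3 (beyond the scatter), showing that this position responds to what it carries. The change lowers inhibition without abolishing it, as compound 3 still gives 25.2%. Nothing available explains the drop. The change adds both the chain extension and the chlorophenoxy end at once, and the compounds shown do not separate them. As far as these compounds go, whether a plain phenoxy or an amine at the chain end would fare differently remains open.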